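This account rests on a few compounds, and the source may have more. Where it says the series, first, only, none or still open, it means among the compounds named here.

Compound 1 `COc1ccc(-c2cc(=O)c3c(OC)cc(OC)cc3n2Cc2ccccc2)cc1` carries a benzyl group on the aromatic nitrogen of the shared core. In a functional assay on KOPN-8 cells (Homo sapiens) for antiproliferative activity, with a stated time of 72 h (a lower number here means that less compound is needed, a higher number that more compound is needed for the effect), compound 1 gives > 17300 nM, which is a limit of the assay and not a number. Compound 2 `COc1ccc(-c2cc(=O)c3c(OC)cc(OC)cc3n2S(=O)(=O)c2ccc(F)cc2)cc1` is the nearest measured neighbour in which that benzyl group is replaced by a sulfonyl group. In this assay compound 2 gives > 65500 nM, again a limit. Compound 3 `COc1ccc(-c2cc(=O)c3c(OC)cc(OC)cc3n2S(=O)(=O)c2cc(Cl)cc(Cl)c2O)cc1` gives > 37900 nM, also a limit. Compound 1 therefore stands at one of three limits, with no measured number among the compounds shown; (the limit of > 17300 nM in this assay, at which 1 of the 3 values shown sits), the limit of > 65500 nM in this assay, at which 1 of the 3 values shown sits, and the limit of > 37900 nM in this assay, at which 1 of the 3 values shown sits, describe the whole set.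

The unmeasured compound 4 `COc1ccc(-c2cc(=O)c3c(OC)cc(OC)cc3n2S(=O)(=O)c2ccc(Br)s2)cc1` differs from compound 1 as follows: (5-bromothiophen-2-yl)sulfonyl in place of benzyl on an aromatic nitrogen. Among the compounds with values here, the steps that bear on this change are a step that the two limits leave unreadable from compound 1 to compound 2 and a step that the two limits leave unreadable from compound 2 to compound 3, neither of which can be read in size or direction because both ends sit at a limit.

Since every sulfonyl analogue so far has remained beyond its limit, compound 4 is expected to behave the same way, and the step that the limit leaves unreadable from compound 1 to compound 4 is estimated to be small or unreadable. For compound 4 the expected value in this assay is 50000 nM, within a range from 15000 nM to 200000 nM.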

Compound 4, half-maximal effective concentration: > 48200 nM
Compound 4: a limit, no number; the forecaster's own chance of this, stated with the estimate: 80%; the middle value does not contradict the limit.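

In this assay compound 4 gives > 48200 nM, a limit and not a number. Within the data shown here, compound 1, compound 2 and compound 3 also stand at limits, so no step to compound 4 can be read in size or direction. The compounds shown leave open whether any group on the aromatic nitrogen of the shared core gives a measurable antiproliferative effect.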